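The compounds below may be only part of what the source reports. "The series", "measured", "known", "first", "only" and "open" are said of these compounds alone.

Working notes on the series. In a functional assay on CHO cells for antagonist activity at corticotropin-releasing factor receptor 1 (Homo sapiens), read by cAMP accumulation (on this read-out lower numbers stand for stronger inhibition and higher numbers for weaker inhibition), compound 3 `Cc1nc(NC(C2CC2)C2CC2)c2nc(C)n(-c3ccc(S(C)(=O)=O)cc3)c2n1` gives 140 nM, the lowest number of the three measured. Compound 1 `COc1ccc(-n2c(CC3CC3)nc3c(NC(C4CC4)C4CC4)nc(C)nc32)cc1` gives 308 nM and compound 2 `COc1ccc(-n2c(C3CCCO3)nc3c(NC(C4CC4)C4CC4)nc(C)nc32)cc1` gives 867 nM. For the measured compounds named here, the single measured step within the set, a 2.8-fold higher number from compound 1 to compound 2 (0.45 log units; beyond the scatter), alters a group elsewhere on the shared core and so does not bear directly on the change now considered. Compound 4 `Cc1nc(NC(C2CC2)C2CC2)c2nc(C)n(-c3ccc(OC(F)(F)F)cc3)c2n1` differs from compound 3 only in trifluoromethoxy in place of methylsulfonyl on an aromatic carbon. Going by the values given here, no measured step touches this position, so the expectation rests on the spread of the three values alone. Compound 4 is expected to give 200 nM, within a range of 60 nM to 700 nM. The expected step of a 1.4-fold higher number from compound 3 to compound 4 (0.15 log units; within the scatter) is therefore no larger than the scatter.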

Compound 4, inhibition constant: 9 nM
Estimate against measurement, compound 4: 22-fold (1.35 log units) above; the measured number lies below the stated range.
By their numbers in this assay, from the lowest: compound 4; then compound 3; then compound 1; then compound 2.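

In this assay, for the compounds shown here, the group on this aromatic carbon, para to a large group, has a strong bearing on the read-out: trifluoromethoxy in place of methylsulfonyl gives a 16-fold lower number from compound 3 to compound 4 (1.19 log units; beyond the scatter) and so sets compound 4 apart from the earlier compounds. The step also shows that the methylsulfonyl group is not needed for a low number here. Nothing measured on these compounds accounts for the size of this step. As far as these compounds go, how an amine or a carboxylic acid on this carbon would read remains open. Also open, from the compounds shown here alone, is whether the step holds with cyclopropylmethyl or oxolan-2-yl elsewhere on the shared core.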